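Working notes on cytotoxicity across compounds 1 to 3

The source may hold more compounds than are shown below. What is called first, only, known or untested is meant among the compounds shown, and "the series" means these compounds.

Measured so far:
compound 1 `CC(C)(C)N(Cc1ccc([N+](=O)[O-])cc1)C(=O)COC(=O)c1ccc([N+](=O)[O-])o1` — > 100000 nM
compound 2 `CC(C)(C)N(Cc1ccc(F)cc1)C(=O)COC(=O)c1ccc([N+](=O)[O-])o1` — > 100000 nM

In an ADME assay on MT4 cells (Homo sapiens) for cytotoxicity, read by MTT assay, with a stated time of 3 days (on this read-out higher numbers stand for lower toxicity in this test and lower numbers for higher toxicity in this test), compound 1 gives > 100000 nM, which is a limit of the assay. Compound 2 gives in this assay > 100000 nM, likewise a limit. The change between them is fluoro in place of nitro on an aromatic carbon, and the step that the two limits leave unreadable from compound 1 to compound 2 has no readable size, since both values sit at the limit of > 100000 nM in this assay, at which 2 of the 2 values shown sit. Within the data shown here, compound 2 thus stands at the limit, and the one further value shown is a limit as well; no number places it more closely.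

Compound 3 `CC(C)(C)N(Cc1ccccc1C(F)(F)F)C(=O)COC(=O)c1ccc([N+](=O)[O-])o1` is unmeasured. It differs from compound 2 by 2-(trifluoromethyl)phenyl in place of 4-fluorophenyl on a saturated chain carbon bound to an amide-type nitrogen. Among the measured compounds shown here, no measured step covers a change of this kind, and the single measured step is unreadable. The expectation therefore rests on both measured values sitting at the limit: compound 3 is expected to stay there, with an estimated step that the limit leaves unreadable from compound 2 to compound 3 not beyond the scatter. Compound 3 is estimated at 150000 nM, in a range from 40000 nM to 400000 nM, most likely reported again only as a limit.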

Compound 3, half-maximal cytotoxic concentration: 95000 nM
Compound 3: the middle estimate sits 1.6-fold (0.20 log units) above what was measured; the range from low to high includes it.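

In this assay, among these compounds, compound 3 gives 95000 nM, the first value that is a number and not a limit. At this saturated chain carbon bound to an amide-type nitrogen, 2-(trifluoromethyl)phenyl in place of 4-fluorophenyl gives an at least 1.0-fold lower number from compound 2 to compound 3 (0.02 log units; that floor lies within the scatter), and in place of 4-nitrophenyl it gives an at least 1.0-fold lower number from compound 1 to compound 3 (0.02 log units; that floor lies within the scatter). These steps are floors only, so the true size of either change stays unknown: the limit of > 100000 nM in this assay, at which 2 of the 3 values shown sit.

The compounds shown leave open how much of the reading in this assay belongs to the trifluoromethyl group and how much to its place on the ring. They also leave open whether an amine or a carboxylic acid on that ring would give a number in the same range.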